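Replacing cyclohexyl with a bicyclic amine on compound 3

The compounds below may be only part of what the source reports. "The series", "measured", "known", "first", "only" and "open" are said of these compounds alone.

Of the compounds shown here, three of one shared core have been measured in a functional assay on the whole organism (blood) with Rattus norvegicus as the target, with stated times of 24 h and 1 h, at a dose of 5 mg/kg by the intraperitoneal route; a lower number here means a weaker effect, a higher number a stronger effect of the compound at the dose given. Compound 1 `Cc1ncsc1C(=O)NCCC1CCN(S(=O)(=O)NC(=O)NC[C@@H]2C[C@@H]3C=C[C@@H]2C3)CC1` gives 11%, and compound 2 `COc1ccncc1C(=O)NCCC1CCN(S(=O)(=O)NC(=O)NC[C@@H]2C[C@@H]3C=C[C@@H]2C3)CC1` gives 14%; the step of a number 3 percentage points higher from compound 1 to compound 2 (within the scatter) shows that exchanging one aromatic amide group for the other leaves the read-out unchanged within the scatter. Compound 3 `O=C(NC1CCCCC1)NS(=O)(=O)N1CCC(CCNC(=O)c2cccc3c2OCCO3)CC1` stands highest of the three in this assay, with 34%, beyond the scatter above both compound 2 and compound 1.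

Compound 4 `O=C(NC[C@@H]1C[C@@H]2C=C[C@@H]1C2)NS(=O)(=O)N1CCC(CCNC(=O)c2cccc3c2OCCO3)CC1` differs from compound 3 in one place: a group of 8 heavy atoms (8 carbon; 2 five-membered non-aromatic rings of carbon only) in place of a group of 6 heavy atoms (6 carbon; one six-membered non-aromatic ring of carbon only), on an amide-type nitrogen. Going by the values given here, no measured step follows this exact change. Compounds 1 and 2 carry the same bicyclic group as compound 4 and both sit low in this assay, while compound 3 with cyclohexyl sits high, but those pairs differ in two places at once, so their values only hint that the bicyclic group may sit at the lower level. He therefore expects a downward step a number 12 percentage points lower from compound 3 to compound 4 (beyond the scatter) beyond the scatter, though with little certainty. His estimate for compound 4 in this assay is 22%, within a range from 8% to 40%.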

Compound 4, a percentage reported as activity, at one dose (the size of the read-out at that dose, not a potency): 11%
For compound 4 the middle estimate is 11 percentage points above the measured one, and the stated range covers the measured number.
By their numbers in this assay, from the lowest: compounds 1, 4 and 2 (each within the scatter of the next); then compound 3.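

In this assay, the exchange of cyclohexyl for the bicyclic group on the amide-type nitrogen now has a direct reading (a number 23 percentage points lower from compound 3 to compound 4 (beyond the scatter)), so with the 2,3-dihydro-1,4-benzodioxin-5-yl amide held constant, this position alone carries a step beyond the scatter. Once the bicyclic group is in place, the aromatic amide group makes no difference that can be read: 2,3-dihydro-1,4-benzodioxin-5-yl in place of 4-methoxypyridin-3-yl gives one step (a number 3 percentage points lower from compound 2 to compound 4 (within the scatter)), and in place of 4-methyl-1,3-thiazol-5-yl gives another (no change at the digits printed from compound 1 to compound 4 (within the scatter)), both within the scatter. Nothing available explains the size of the step at this position.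

Cyclohexyl appears here only in compound 3, so it remains open whether the same step would follow with the 4-methoxypyridin-3-yl or 4-methyl-1,3-thiazol-5-yl amide. On these data alone, it is also open which feature of the entering group goes with the lower number, a question that a cyclohexylmethyl group or the bicyclic group without its double bond could help to separate.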